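Compound 3 Tested Against a Cytotoxicity Limit

This account rests on a few compounds, and the source may have more. Where it says the series, first, only, none or still open, it means among the compounds named here.

Compound 1 `COc1cc2ncnc(-n3nc(-c4ccccn4)nc3N)c2cc1N` gives "not determined" (no result reported)
Compound 2 `COc1cc2ncnc(-n3nc(-c4ccccn4)nc3N)c2cc1OCCCN1CC(C)OC(C)C1` gives > 25000 nM

In an ADME assay on BJ cells (Homo sapiens) for cytotoxicity, with a stated time of 72 h (on this read-out lower numbers stand for an effect already at smaller amounts and higher numbers for an effect only at larger amounts of compound), compound 2 stands at > 25000 nM which is a limit of the assay and not a number. For compound 1 the record reads "not determined" (no result reported) and offers no comparison.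

The next compound is compound 3 `COc1cc2ncnc(-n3nc(-c4ccccn4)nc3N)c2cc1OCCCNC(=O)OC(C)(C)C` which shares its core and its propyl chain with compound 2. The change is (tert-butoxycarbonyl)amino in place of 2,6-dimethylmorpholin-4-yl on a saturated chain carbon, three bonds along the chain from an oxygen on an aromatic ring and reads in words: (tert-butoxycarbonyl)amino in place of 2,6-dimethylmorpholin-4-yl on a saturated chain carbon, three bonds along the chain from an oxygen on an aromatic ring.

Within the data shown here, no measured pair shows a swap of this kind, so any forecast is rough. It rests on compound 2 at > 25000 nM as its only anchor, and that anchor is a limit. The expected change, a number no higher from compound 2 to compound 3 (the limit leaves the size open) as estimated here, stays within the usual scatter, in neither direction. In this assay compound 3 is expected at 25000 nM with an estimated range from 10000 nM to 60000 nM and the assay may again report only a limit.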

Compound 3, half-maximal effective concentration: > 12000 nM
Compound 3 ended at the assay's limit; the forecaster's own chance of this, stated with the estimate: 75%; the middle value does not contradict the limit.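

Among these compounds, compound 2 and compound 3 each end at a limit of this assay and not at a number, so no step between them can be read. The compounds shown leave open at what concentration either one reaches its half-maximal effect on these cells, and whether (tert-butoxycarbonyl)amino in place of 2,6-dimethylmorpholin-4-yl changes that concentration.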